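Amide variation on a shared core: tolerated concentration notes

This account rests on a few compounds, and the source may have more. Where it says the series, first, only, none or still open, it means among the compounds named here.

Compound 1 `CCC(=O)Nc1ncc(-c2ccc(OC)cc2)n1C` gives in a toxicity assay on THP-1 cells (Homo sapiens) for inhibition (a higher number here means that more compound is tolerated, a lower number that less compound is tolerated), the value > 100000 nM, which is a limit of the assay. Compound 2 `COc1ccc(-c2cnc(NC(=O)CCc3ccccc3)n2C)cc1` gives in this assay the value > 100000 nM, again a limit. Compound 3 `COc1ccc(-c2cnc(NC(=O)c3ccccc3C#N)n2C)cc1` gives in this assay the value > 100000 nM, also a limit.

Compound 3 therefore stands at the limit, as do the other two values (the limit of > 100000 nM in this assay, at which 3 of the 3 values shown sit). The steps a step that the two limits leave unreadable from compound 1 to compound 3 and a step that the two limits leave unreadable from compound 2 to compound 3 are unreadable, and a step that the two limits leave unreadable from compound 1 to compound 2 likewise. Compound 4 `COc1ccc(-c2cnc(NC(=O)c3ccn[nH]3)n2C)cc1` differs from compound 3 as follows: 1H-pyrazol-5-yl in place of 2-cyanophenyl on a carbonyl carbon. Among the measured compounds shown here, no measured step bears readably on this change, so no step beyond the scatter in this assay is expected, and compound 4 is estimated at 100000 nM (range 40000 nM to 300000 nM), an expected step of a number no higher from compound 3 to compound 4 (the limit leaves the size open).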

Compound 4, half-maximal cytotoxic concentration: > 100000 nM
Compound 4 was reported as a limit; the forecaster's own chance of this, stated with the estimate: 85%; the middle value lies on the limit itself.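

Compound 4 joins compound 1, compound 2 and compound 3 as a limit in this assay, so no step among them can be read: the limit of > 100000 nM in this assay, at which 4 of the 4 values shown sit.

The compounds shown leave open whether any amide variation on the shared core changes the tolerated concentration.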